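The source may report more compounds than this note shows. Statements on the series, on what has been measured and on what is new or still open speak of the compounds shown alone.

Compound 1 `O=C(O)c1csc(SCCN2C(=O)CC[C@@H]2/C=C/[C@@H](O)Cc2cccc(-c3ccccc3)c2)n1`: 8 nM
Compound 2 `Cc1ccc2oc(-c3cccc(C[C@H](O)/C=C/[C@H]4CCC(=O)N4CCSc4nc(C(=O)O)cs4)c3)nc2c1`: 8.8 nM

Of the compounds shown here, two sharing one core have been measured in a functional assay on CHO cells for agonist activity at prostaglandin E2 receptor EP4 subtype (Rattus norvegicus), read by cAMP accumulation and immunoassay, with a stated time of 10 min; on this read-out lower numbers stand for an effect already at smaller amounts and higher numbers for an effect only at larger amounts of compound. Compound 1 `O=C(O)c1csc(SCCN2C(=O)CC[C@@H]2/C=C/[C@@H](O)Cc2cccc(-c3ccccc3)c2)n1` gives 8 nM in this assay, and compound 2 `Cc1ccc2oc(-c3cccc(C[C@H](O)/C=C/[C@H]4CCC(=O)N4CCSc4nc(C(=O)O)cs4)c3)nc2c1` gives 8.8 nM. Within the data shown here, the one step between them, a 1.1-fold higher number from compound 1 to compound 2 (0.04 log units; within the scatter), shows that exchanging phenyl for 5-methyl-1,3-benzoxazol-2-yl left the read-out essentially unchanged. Compound 2 therefore holds the highest of the two numbers, yet its separation from compound 1 lies within the scatter, so no order between them can be drawn.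

Compound 3 `Cc1cc(C)c2oc(-c3cccc(C[C@H](O)/C=C/[C@H]4CCC(=O)N4CCSc4nc(C(=O)O)cs4)c3)nc2c1` has not yet been measured. It differs from compound 2 by methyl in place of hydrogen on an aromatic carbon, so the 5-methyl-1,3-benzoxazol-2-yl group becomes 5,7-dimethyl-1,3-benzoxazol-2-yl. Among the measured compounds shown here, no measured step adds a methyl to this part of the molecule; the only step known, from compound 1 to compound 2, concerns a different exchange on the same aromatic carbon and was within the scatter. The expected step from compound 2 to compound 3 in this assay is therefore a 1.1-fold higher number from compound 2 to compound 3 (0.06 log units; within the scatter), not beyond the scatter. Compound 3 is estimated at 10 nM, within a range of 4 nM to 25 nM.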

Compound 3, half-maximal effective concentration: 7.7 nM
Compound 3: the middle estimate sits 1.3-fold (0.11 log units) above what was measured; the range from low to high includes it.
By their numbers in this assay, from the lowest: compounds 3, 1 and 2 (each within the scatter of the next).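

Adding a methyl on an aromatic carbon of the six-membered ring of carbon only, which turns 5-methyl-1,3-benzoxazol-2-yl into 5,7-dimethyl-1,3-benzoxazol-2-yl, gives no difference beyond the scatter in this assay (a 1.1-fold lower number from compound 2 to compound 3 (0.06 log units; within the scatter)). The earlier pair had shown only an exchange of phenyl for the whole 5-methyl-1,3-benzoxazol-2-yl group, whereas this result shows that a further methyl on that ring also keeps the number within the scatter, and the comparison with the phenyl compound reads the same (a 1.0-fold lower number from compound 1 to compound 3 (0.02 log units; within the scatter)). Nothing given here offers an explanation for this absence of a difference.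

The compounds shown leave open whether this position would accept something other than methyl, such as an amine, a carboxylic acid or a longer chain such as propyl, with the number staying within the scatter. They also leave open how the unsubstituted 1,3-benzoxazol-2-yl group would read, so the contribution of the methyl already present in compound 2 cannot be judged.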